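The compounds below may be only part of what the source reports. "The series", "measured", "known", "first", "only" and "open" are said of these compounds alone.

Measured in a functional assay on HL-60 cells (Homo sapiens) for inhibition, read by CCK-8 assay, with a stated time of 48 h; a higher number here means a weaker inhibitor, a lower number a stronger inhibitor:

- compound 1 `O=[N+]([O-])c1ccc(NC(=S)NCCNS(=O)(=O)c2ccc(-c3ccccc3O[C@H]3CC[C@@H](O)CC3)s2)cc1`: > 50000 nM (a limit)
- compound 2 `O=[N+]([O-])c1ccc(NC(=S)NCCNS(=O)(=O)c2ccc(-c3ccccc3OCc3cccc(O)c3)s2)cc1`: 10800 nM
- compound 3 `O=C(NCCNS(=O)(=O)c1ccc(-c2ccccc2O[C@H]2CC[C@H](O)CC2)s1)Nc1cc(Cl)cc(Cl)c1`: > 20000 nM (a limit)

Compound 3 is weak on these numbers. Going by these compounds, its > 20000 nM is a limit and not a number, so its true position is unknown.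

Compound 4 `O=[N+]([O-])c1ccc(NC(=S)NCCNS(=O)(=O)c2ccc(-c3ccccc3O[C@H]3CC[C@H](O)CC3)s2)cc1` keeps the 4-hydroxycyclohexyl group of compound 3 and differs from it in one place: a group of 12 heavy atoms (7 carbon, 2 nitrogen, 2 oxygen, 1 sulfur; one six-membered aromatic ring of carbon only) in place of a group of 11 heavy atoms (7 carbon, 1 nitrogen, 1 oxygen, 2 chlorine; one six-membered aromatic ring of carbon only), on an amine nitrogen. The group that leaves is (3,5-dichlorophenyl)carbamoyl.

Going by the values given here, no measured step makes this swap. Among the compounds with values here, the only step available, an at least 4.6-fold lower number from compound 1 to compound 2 (0.66 log units; beyond the scatter), places 3-hydroxybenzyl where 4-hydroxycyclohexyl stood, which is a different part of the molecule. It bears only indirectly, since compound 1 and compound 2 both already carry the group entering compound 4. Compound 1 is the closest relative of compound 4, with the same groups but the 4-hydroxycyclohexyl drawn in the other spatial arrangement, and its result in this assay is also a limit.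

With no direction set by these data, no change beyond the scatter is expected, and another limit could well be reported. The expected step is a step that the limit leaves unreadable from compound 3 to compound 4. For compound 4 the estimated value is 30000 nM, with an estimated range of 12000 nM to 60000 nM.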

Compound 4, half-maximal inhibitory concentration: 11600 nM
Compound 4: middle estimate off by 2.6-fold (0.41 log units), on the high side; the measured number lies below the stated range.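

The spatial arrangement of the 4-hydroxycyclohexyl group makes a real difference in this assay, with an at least 4.3-fold lower number from compound 1 to compound 4 (0.63 log units; beyond the scatter), and the cause can be narrowed to that arrangement alone: the fact that compounds 1 and 4 differ only in the configuration as drawn

At the same place, on the oxygen on the aromatic ring, the 4-hydroxycyclohexyl group of compound 4 and the 3-hydroxybenzyl group of compound 2 cannot be told apart, at a 1.1-fold higher number from compound 2 to compound 4 (0.03 log units; within the scatter), so a saturated ring in the right arrangement does as well here as the aromatic one. The change on the amine nitrogen, with (3,5-dichlorophenyl)carbamoyl leaving, gives an at least 1.7-fold lower number from compound 3 to compound 4 (0.23 log units; that floor lies within the scatter), and since this step rests on a limit for compound 3, it establishes no real change.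

Whether the same spatial effect appears when (3,5-dichlorophenyl)carbamoyl sits on the amine nitrogen stays open, since compound 3 has no mirror-image partner among the compounds shown. Going by these compounds, it is also open how an amine or a carboxylic acid in place of the hydroxyl on the cyclohexyl ring would fare in this assay.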